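Aryl swap on the shared core: working notes

A few compounds are considered here, and "the series" means these few. Any claim that something is new, unique, unknown or untested is made for them only; others in the source may bear on it.

Measured so far:
compound 1 `O=[N+]([O-])c1ccccc1CNc1cc(Br)cc2cn[nH]c12` — > 100000 nM in an assay for inhibition of Tryptophan 2,3-dioxygenase (Homo sapiens), with stated times of 10 min and 60 min; a lower number here means a stronger inhibitor, a higher number a weaker inhibitor
compound 2 `Nc1cccc(CNc2cc(C(F)(F)F)cc3[nH]ncc23)c1` — 2510 nM in this assay

For compound 1 the value in this assay is a limit of the assay, not a number, and the limit of > 100000 nM in this assay, at which 1 of the 2 values shown sits, is the only such case. Among the measured compounds shown here, compound 2 therefore supplies the only number in this assay so far, and every comparison rests on it.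

Compound 3 `Oc1ccc(CNc2cc(C(F)(F)F)cc3[nH]ncc23)cc1` is not yet measured. It differs from compound 2 in one place: 4-hydroxyphenyl in place of 3-aminophenyl on a saturated chain carbon bound to a nitrogen on an aromatic ring. For the measured compounds named here, both groups leaving and entering carry one hydrogen-bond donor and one acceptor, and no measured step of this kind exists, so there is nothing to scale the change against.

The expected step from compound 2 to compound 3 in this assay is a 1.4-fold higher number from compound 2 to compound 3 (0.14 log units; within the scatter), that is, no change beyond the usual scatter, with a slight lean toward weaker. Compound 3 is accordingly estimated at 3500 nM, within 1000 nM to 12000 nM.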

Compound 3, half-maximal inhibitory concentration: 2550 nM
Estimate against measurement, compound 3: 1.4-fold (0.14 log units) above, and the stated range covers the measured number.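

Read in this assay, 4-hydroxyphenyl in place of 3-aminophenyl on a saturated chain carbon bound to a nitrogen on an aromatic ring gives a 1.0-fold higher number from compound 2 to compound 3 (0.01 log units; within the scatter) and is the only step in the series that can be read. The two groups therefore cannot be told apart at this place, although the swap changes both the ring substituent and where it stands on the phenyl ring. No measurement shown bears on why the two groups read alike.

Still open, going by these compounds, is whether either the amine or the hydroxyl contributes at all, which plain phenyl would test, and whether 4-aminophenyl or 3-hydroxyphenyl reads the same. Also open, on these data alone, is how far this tolerance extends, for instance to a carboxylic acid on the phenyl ring or to a longer chain.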